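A few compounds are considered here, and "the series" means these few. Any claim that something is new, unique, unknown or untested is made for them only; others in the source may bear on it.

Compound 1 `COc1cc(/C=N/N(C(=O)c2ccccc2)C(=O)c2ccncc2)ccc1O`: >= 100 ug/mL
Compound 2 `CSc1ccc(/C=N/N(C(=O)c2ccccc2)C(=O)c2ccncc2)cc1`: >= 100 ug/mL

In an ADME assay on Vero cells (Chlorocebus sabaeus) for cytotoxicity (a higher number here means that more compound is tolerated, a lower number that less compound is tolerated), compound 2 gives >= 100 ug/mL, which is a limit of the assay and not a measured number. Going by the values given here, the single step toward it, a step that the two limits leave unreadable from compound 1 to compound 2, is unreadable because of the limit of >= 100 ug/mL in this assay, at which 2 of the 2 values shown sit. Compound 3 `CSc1ccc(/C=N/NC(=O)c2ccncc2)cc1` differs from compound 2 by hydrogen in place of benzoyl on an amide-type nitrogen. Among the compounds with values here, no measured step resembles this change, so nothing points to a shift in either direction. Compound 3 is therefore expected to sit at about the same level, with the step of a number no higher from compound 2 to compound 3 (the limit leaves the size open) estimated as none beyond the scatter. The estimate for compound 3 is 100 ug/mL, ranging from 50 ug/mL to 200 ug/mL.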

Compound 3, minimum cytotoxic concentration: >= 100 ug/mL
Compound 3 gave a limit, no number (the forecaster's own chance of this, stated with the estimate: 70%); the middle value sits exactly at the limit.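

The step between compound 2 and compound 3 cannot be read, because both compounds sit at a limit and give no number: the limit of >= 100 ug/mL in this assay, at which 3 of the 3 values shown sit. The compounds shown leave open whether hydrogen in place of benzoyl changes how much compound the cells tolerate.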